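A few compounds are considered here, and "the series" means these few. Any claim that something is new, unique, unknown or untested is made for them only; others in the source may bear on it.

Values so far in a functional assay on MCF7 cells (Homo sapiens) for inhibition, read by MTT assay, with a stated time of 72 h; a higher number here means a weaker inhibitor, a lower number a stronger inhibitor
compound 1 `Cc1ccc(C(C)C)c(OCc2cn(-c3ccc(O)cc3)nn2)c1` gives 45400 nM
compound 2 `Cc1ccc(C(C)C)c(OCc2cn(-c3ccccc3Cl)nn2)c1` gives 15600 nM
compound 3 `Cc1ccc(C(C)C)c(OCc2cn(-c3ccc(F)cc3)nn2)c1` gives 22100 nM

Compound 3 does not carry the highest of the three numbers, and it cannot be told apart from compound 2. The gap on that side is a 1.4-fold higher number from compound 2 to compound 3 (0.15 log units; within the scatter) and the gap on the other side is a 2.1-fold lower number from compound 1 to compound 3 (0.31 log units; beyond the scatter) in this series.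

Compound 4 `Cc1cccc(-n2cc(COc3cc(C)ccc3C(C)C)nn2)c1` has 3-methylphenyl in place of 4-fluorophenyl on an aromatic nitrogen. Going by the values given here, no measured step puts a methyl group on this phenyl, so the evidence is indirect. Replacing the 4-hydroxyphenyl of compound 1 gave two modest steps, a 2.9-fold lower number from compound 1 to compound 2 (0.46 log units; beyond the scatter) and a 2.1-fold lower number from compound 1 to compound 3 (0.31 log units; beyond the scatter) in turn. The exchange between the two halogen-bearing phenyl groups gave a 1.4-fold higher number from compound 2 to compound 3 (0.15 log units; within the scatter) and stayed within the scatter. Compound 4 also lacks the hydroxy group, so a value near those of compound 2 and compound 3 is expected, with no step beyond the scatter. The expected change is a 1.1-fold lower number from compound 3 to compound 4 (0.04 log units; within the scatter) and no more. In this assay the estimated value for compound 4 is 20000 nM within an expected range of 10000 nM to 40000 nM overall.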

Compound 4, half-maximal inhibitory concentration: 28100 nM
Beside the measured number, compound 4's estimate is 1.4-fold (0.15 log units) below it, and the stated range covers the measured number.
By their numbers in this assay, from the lowest: compounds 2, 3, 4 and 1 (each within the scatter of the next, the first and the last beyond it).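

In this assay, 3-methylphenyl on the aromatic nitrogen cannot be told apart from either halogen-bearing phenyl group: a 1.3-fold higher number from compound 3 to compound 4 (0.10 log units; within the scatter) and a 1.8-fold higher number from compound 2 to compound 4 (0.26 log units; within the scatter) both stay within the scatter, so among these compounds a halogen on this phenyl is not required for a value in this range. The new information concerns the hydroxy end of the series: a 1.6-fold lower number from compound 1 to compound 4 (0.21 log units; within the scatter) also stays within the scatter, so compound 4 goes against the reading, suggested by compounds 2 and 3, that replacing the 4-hydroxyphenyl always gives a step beyond the scatter. Nothing available here accounts for these differences or their absence.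

From the compounds shown here alone, only the phenyl group on the aromatic nitrogen varies across the four compounds, so it remains open what an amine, a carboxylic acid or a propyl chain on this phenyl would give. The rest of the shared core is the same throughout, which leaves open whether a change there could move the number further than any step seen at this position.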